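A sulfone replaces the sulfonamide substituent of compound 2

This account rests on a few compounds, and the source may have more. Where it says the series, first, only, none or still open, it means among the compounds named here.

Compound 1, `N=C(N)NS(=O)(=O)c1ccc(N/C=C\C(=O)c2cc3ccccc3oc2=O)cc1`: 87600 nM
Compound 2, `Cc1cc(NS(=O)(=O)c2ccc(N/C=C\C(=O)c3cc4ccccc4oc3=O)cc2)nc(C)n1`: 100000 nM

In a functional assay on T47D cells (Homo sapiens) for cytotoxicity, read by sulforhodamine B assay, with a stated time of 48 h (a higher number here means a weaker inhibitor, a lower number a stronger inhibitor), compound 2 gives 100000 nM. On these two numbers compound 2 is separated from compound 1 only by a 1.1-fold higher number from compound 1 to compound 2 (0.06 log units; within the scatter), so the two stand together rather than apart. Compound 3, `Nc1ccc(S(=O)(=O)c2ccc(N/C=C\C(=O)c3cc4ccccc4oc3=O)cc2)cc1`, carries 4-aminophenyl in place of (2,6-dimethylpyrimidin-4-yl)amino on a sulfonyl sulfur. Among the measured compounds shown here, the single measured step, the one from compound 1 to compound 2, also exchanged the group on the sulfonamide nitrogen and moved the number by a 1.1-fold higher number from compound 1 to compound 2 (0.06 log units; within the scatter). For the measured compounds named here, the change to compound 3 goes further, removing that nitrogen altogether, and no measured step covers such a change; the shared core with its coumarin-bearing enaminone is kept. The expectation is therefore a step of a 1.1-fold lower number from compound 2 to compound 3 (0.05 log units; within the scatter) in this assay, not beyond the scatter, with a wide margin. Compound 3 is estimated at 90000 nM, between 30000 nM and 300000 nM.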

Compound 3, half-maximal inhibitory concentration: 91900 nM
For compound 3 the middle estimate is 1.0-fold (0.01 log units) below the measured one; the measured number falls inside the stated range.
By their numbers in this assay, from the lowest: compounds 1, 3 and 2 (each within the scatter of the next).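

In this assay, taking away the sulfonamide nitrogen and setting 4-aminophenyl on the sulfonyl sulfur gives a step that stays within the scatter (a 1.1-fold lower number from compound 2 to compound 3 (0.04 log units; within the scatter)). Among the compounds shown here, the earlier compounds showed only that the group on the sulfonamide nitrogen could be exchanged without a separable difference; compound 3 shows that the same holds for a sulfone, which has no such nitrogen, and the comparison with the group of compound 1 agrees (a 1.0-fold higher number from compound 1 to compound 3 (0.02 log units; within the scatter)). No evidence is at hand on why these groups on the sulfonyl sulfur read alike.

From the compounds shown here alone, whether a carboxylic acid or a short alkyl chain on the sulfonyl sulfur would separate from these three remains open. So does whether this number responds to any change in the shared core.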